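The source may hold more compounds than are shown below. What is called first, only, known or untested is meant among the compounds shown, and "the series" means these compounds.

Compound 1 `CC(/N=c1\c(O)c(O)\c1=N/c1cncc(Br)c1)C(C)(C)C`: 11700 nM
Compound 2 `CCC/N=c1\c(O)c(O)\c1=N/c1cccnc1`: > 30000 nM (a limit)
Compound 3 `CC(/N=c1\c(O)c(O)\c1=N/c1ccc(S(N)(=O)=O)cc1)C(C)(C)C`: > 30000 nM (a limit)

All three compounds were tested in a functional assay for inhibition, with Rattus norvegicus as the target (a higher number here means a weaker inhibitor, a lower number a stronger inhibitor), and only compound 1 returned a number. Compound 3 gave no number, only a limit: it stands at the limit of > 30000 nM in this assay, at which 2 of the 3 values shown sit. How far its true value lies from that limit is not known.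

Compound 4 `CC(/N=c1\c(O)c(O)\c1=N/c1ccc(-n2ccnc2)cc1)C(C)(C)C` has not yet been measured. It carries 1H-imidazol-1-yl in place of sulfamoyl on an aromatic carbon, para to a large group: 1H-imidazol-1-yl in place of sulfamoyl on an aromatic carbon. Among the compounds with values here, no measured pair of compounds isolates this change, so the expectation for this assay rests on little. Within the data shown here, the only number available is that of compound 1 with 11700 nM, so a modest shift toward stronger inhibition is expected. The result for compound 4 may equally remain at the limit. The expected size is an at least 1.5-fold lower number from compound 3 to compound 4 (0.17 log units; that floor lies within the scatter). For compound 4 the estimated value is 20000 nM, with an expected range from 5000 nM to 60000 nM.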

Compound 4, half-maximal inhibitory concentration: > 30000 nM
Compound 4: no number, only a limit; the forecaster's own chance of this, stated with the estimate: 45%; middle value at least 1.5-fold (0.17 log units) from the limit.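

Within the data shown here, compound 3 and compound 4 each gave only a limit in this assay, so no step between them can be read: the limit of > 30000 nM in this assay, at which 3 of the 4 values shown sit. The compounds shown leave open whether 1H-imidazol-1-yl in place of sulfamoyl shifts inhibition at all, and in which direction.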